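Nitrobenzyl thioether on the isomeric core: expected cytotoxicity

The compounds below may be only part of what the source reports. "The series", "measured", "known", "first", "only" and "open" are said of these compounds alone.

Measured compounds:
compound 1 `Cn1nc(-c2nnc(SCc3cccc([N+](=O)[O-])c3)o2)cc1-c1ccc(C(F)(F)F)cc1` – > 100000 nM
compound 2 `Cn1nc(-c2nnc(SCc3ccc(Cl)cc3F)o2)cc1-c1ccc(C(F)(F)F)cc1` – 26200 nM
compound 3 `Cn1nc(-c2ccc(C(F)(F)F)cc2)cc1-c1nnc(SCc2c(F)cccc2F)o1` – 38500 nM

In a functional assay on Ehrlich cells (Mus musculus) for cytotoxicity, read by MTT assay, with a stated time of 24 h (on this read-out higher numbers stand for weaker inhibition and lower numbers for stronger inhibition), compound 1 gives > 100000 nM, which is a limit of the assay and not a number. Compound 2 gives 26200 nM and compound 3 gives 38500 nM. Compound 3 therefore holds the highest of the two numbers that were obtained; its nearest neighbour is compound 2, and the gap between them lies within the scatter.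

Compound 4 `Cn1nc(-c2ccc(C(F)(F)F)cc2)cc1-c1nnc(SCc2cccc([N+](=O)[O-])c2)o1` differs from compound 3 by 3-nitrophenyl in place of 2,6-difluorophenyl on a saturated chain carbon bound to a sulfur. For the measured compounds named here, the only measured step that bears on this change is an at least 3.8-fold lower number from compound 1 to compound 2 (0.58 log units; beyond the scatter), which runs in the opposite direction and replaces the nitrobenzyl group on the other arrangement of the core, where compound 1 sits at the limit (the limit of > 100000 nM in this assay, at which 1 of the 3 values shown sits). Read backwards, that step suggests that returning the nitrobenzyl group should push the number upward, quite possibly past the upper limit again. Compound 4 is thus expected to show a 3.9-fold higher number from compound 3 to compound 4 (0.59 log units; beyond the scatter), and its estimated value is 150000 nM, between 40000 nM and 500000 nM.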

Compound 4, half-maximal inhibitory concentration: > 100000 nM
Compound 4 ended at the assay's limit; the forecaster's own chance of this, stated with the estimate: 60%; the middle value lies beyond the limit too.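

In this assay, the change from 2,6-difluorobenzyl to 3-nitrobenzyl on a saturated chain carbon bound to a sulfur gives an at least 2.5-fold higher number from compound 3 to compound 4 (0.41 log units; beyond the scatter), so the upward direction seen when the earlier step is read backwards also appears on this arrangement of the core. As far as these compounds go, compound 4 gives > 100000 nM, which is a limit of the assay and not a number, so the full size of the step remains unknown. The 3-nitrobenzyl group now stands at the limit on both arrangements of the core, in compound 1 and compound 4: the limit of > 100000 nM in this assay, at which 2 of the 4 values shown sit.

The compounds shown cannot tell how the two arrangements of the core compare with this group attached. From the compounds shown here alone, it also remains open whether an amine or a carboxylic acid in place of the nitro group would bring the number back within the range of the assay.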